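The compounds below may be only part of what the source reports. "The series", "measured", "known", "first", "only" and "open" are said of these compounds alone.

Measured in a functional assay on U2OS cells (Homo sapiens) for antiproliferative activity, read by MTT assay, with a stated time of 72 h; a higher number here means a weaker inhibitor, a lower number a stronger inhibitor:

compound 1, `CCOC1=C(C(=O)c2ccccc2)C(c2ccc(Br)cc2)N(CCCn2ccnc2)C1=O`, gives 21900 nM
compound 2, `O=C(C1=C(OC2CCCCC2)C(=O)N(CCCn2ccnc2)C1c1ccc(Br)cc1)c1ccccc1`, gives 22400 nM
compound 3, `Cc1ccc(NC2=C(C(=O)c3ccccc3)C(c3ccc(Br)cc3)N(CCCn3ccnc3)C2=O)cc1`, gives 24100 nM

Compound 2 stands among the three with neither neighbour separated from it beyond the scatter: the step of a 1.0-fold higher number from compound 1 to compound 2 (0.01 log units; within the scatter) and the step of a 1.1-fold higher number from compound 2 to compound 3 (0.03 log units; within the scatter) are both small. Compound 4, `O=C(C1=C(Nc2ccc(Br)cc2)C(=O)N(CCCn2ccnc2)C1c1ccc(Br)cc1)c1ccccc1`, differs from compound 2 by one change, ((4-bromophenyl)amino in place of cyclohexyloxy on a double-bonded ring carbon).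

Among the compounds with values here, two measured steps bear on this change. The step of a 1.1-fold higher number from compound 2 to compound 3 (0.03 log units; within the scatter) swaps the same cyclohexyloxy for a (4-methylphenyl)amino group at the same ring carbon, and the step of a 1.1-fold higher number from compound 1 to compound 3 (0.04 log units; within the scatter) brings the same kind of amino group in for ethoxy; neither moved the number beyond the scatter. Within the data shown here, the only novelty in compound 4 is the bromine on the entering phenyl ring, for which no measured pair exists. Compound 4 is therefore expected to show a step of a 1.0-fold higher number from compound 2 to compound 4 (0.01 log units; within the scatter), that is, nothing beyond the scatter in this assay. The estimate for compound 4 is 23000 nM, with a range from 9000 nM to 60000 nM.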

Compound 4, half-maximal inhibitory concentration: 13000 nM
The estimate for compound 4 lay 1.8-fold (0.25 log units) above the measured number; low and high end bracket the measured number.
By their numbers in this assay, from the lowest: compounds 4, 1, 2 and 3 (each within the scatter of the next).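

In this assay, the (4-bromophenyl)amino group at this double-bonded ring carbon replaces cyclohexyloxy (a 1.7-fold lower number from compound 2 to compound 4 (0.24 log units; within the scatter)) and ethoxy (a 1.7-fold lower number from compound 1 to compound 4 (0.23 log units; within the scatter)) without leaving the scatter. Within the data shown here, the bromine on the entering phenyl ring, which no earlier pair could address, now has its own comparison: bromo in place of methyl on an aromatic carbon gives a step that also stays within the scatter (a 1.9-fold lower number from compound 3 to compound 4 (0.27 log units; within the scatter)). Across these four compounds, then, neither oxygen-linked nor nitrogen-linked groups at this position separate beyond the scatter, and nothing available explains this closeness.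

On these data alone, whether a carboxylic acid or a piperidine at this ring carbon would move the number beyond the scatter remains open. So does the effect of a longer chain in place of the 3-(1H-imidazol-1-yl)propyl group.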